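Aryl versus carbamoyl substituent on the saturated ring carbon

The compounds below may be only part of what the source reports. "The series", "measured", "known", "first", "only" and "open" are said of these compounds alone.

Measured so far:
- compound 1 `Cc1nn(-c2ncnc3nc[nH]c23)c2c1C(c1ccc(OC(C)C)cc1)CC(=O)N2`: 18 nM
- compound 2 `Cc1nn(-c2ncnc3nc[nH]c23)c2c1C(C(=O)N(C)c1nccs1)CC(=O)N2`: 18 nM

In a functional assay on HEK293 cells for agonist activity at G-protein coupled receptor 39 (Homo sapiens), read by scintillation proximity assay and inositol phosphate accumulation, with a stated time of 75 min, in the presence of a further agent that is not named here (a higher number here means that more compound is needed for the effect, a lower number that less compound is needed), compound 1 gives 18 nM. Compound 2, which carries methyl(1,3-thiazol-2-yl)carbamoyl in place of 4-isopropoxyphenyl on the saturated ring carbon, gives 18 nM in this assay. The step of no change at the digits printed from compound 1 to compound 2 (within the scatter) shows that swapping an aromatic substituent for a carbamoyl group at this position left the result unchanged within the scatter, so compound 2 stands level with compound 1 on the numbers available.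

Compound 3 `Cc1nn(-c2ncnc3nc[nH]c23)c2c1C(c1ccc(F)cc1Cl)CC(=O)N2` is the next compound for this assay. The difference from compound 2 is 2-chloro-4-fluorophenyl in place of methyl(1,3-thiazol-2-yl)carbamoyl on a saturated ring carbon. For the measured compounds named here, the only step that bears on it is no change at the digits printed from compound 1 to compound 2 (within the scatter), which returns to an aromatic ring on the same carbon, now halogenated rather than bearing isopropoxy, and that step was flat. Going by the values given here, no measured pair speaks to the effect of halogen substitution on the ring, so no direction beyond the scatter is expected.

Compound 3 is expected to give 20 nM in this assay, with a range from 7 nM to 60 nM. The step of a 1.1-fold higher number from compound 2 to compound 3 (0.05 log units; within the scatter) is therefore estimated to lie within the scatter.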

Compound 3, half-maximal effective concentration: 9 nM
Beside the measured number, compound 3's estimate is 2.2-fold (0.35 log units) above it, and the stated range covers the measured number.
By their numbers in this assay, from the lowest: compounds 3, 1 and 2 (each within the scatter of the next).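

In this assay, 2-chloro-4-fluorophenyl on the saturated ring carbon reads alike with both earlier groups: the steps are a 2.0-fold lower number from compound 2 to compound 3 (0.30 log units; within the scatter) and a 2.0-fold lower number from compound 1 to compound 3 (0.30 log units; within the scatter). This position has now carried methyl(1,3-thiazol-2-yl)carbamoyl, 4-isopropoxyphenyl and 2-chloro-4-fluorophenyl with every step inside the scatter, so the flat result of the earlier pair does not depend on the isopropoxy group, and it holds even though the entering group counts 0 hydrogen-bond acceptors against 3 in the carbamoyl group it replaces. Nothing at hand gives a reason for this flatness.

The substituents shown at this carbon are all large and ring-bearing, so it remains open whether a small group without a ring, such as a methyl, a primary amine or a carboxylic acid, would read the same. Also open is what the chlorine and the fluorine each contribute, since an unsubstituted phenyl and the singly halogenated phenyl rings are not among the compounds shown here.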